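This account rests on a few compounds, and the source may have more. Where it says the series, first, only, none or still open, it means among the compounds named here.

Measured compounds:
compound 1, `Clc1ccc(C(/C=C/c2ccccc2)=N\Nc2nncc3ccccc23)cc1`, 5.7 nM
compound 2, `NC(=S)NNc1nncc2ccccc12`, 55 nM
compound 3, `O=S(=O)(Nc1ccccn1)c1ccc(Nc2nncc3ccccc23)cc1`, 44 nM

Of the compounds shown here, three built on the shared core have been measured in a functional assay on COLO 205 cells (Homo sapiens) for antiproliferative activity, read by sulforhodamine B assay, with a stated time of 72 h; a higher number here means a weaker inhibitor, a lower number a stronger inhibitor. Compound 1 gives 5.7 nM, the lowest number of the three. Compound 3, with 44 nM, and compound 2, with 55 nM, both stand well beyond the scatter from it, so compound 1 is the strongest inhibitor of this set.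

Compound 4, `C(=C/c1ccccc1)\C(=N\Nc1nncc2ccccc12)c1ccccc1`, has not yet been measured in this assay. It differs from compound 1 in a single place: hydrogen in place of chloro on an aromatic carbon. Among the compounds with values here, no measured pair in this set shows the effect of such a change, so the step can only be estimated from the general size of substituent effects on an aromatic ring. Because compound 1 gives 5.7 nM, compound 4 is expected to remain a strong inhibitor, with a step from a 2.1-fold higher number from compound 1 to compound 4 (0.32 log units; beyond the scatter) expected to be small, toward a somewhat higher number, and perhaps not beyond the scatter. The estimate for compound 4 is 12 nM, within a range of 4 nM to 40 nM.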

Compound 4, half-maximal inhibitory concentration: 2.4 nM
Compound 4: middle estimate off by 5.0-fold (0.70 log units), on the high side, and the stated range ends above it.
By their numbers in this assay, from the lowest: compound 4; then compound 1; then compounds 3 and 2 (each within the scatter of the next).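

In this assay the change from 4-chlorophenyl to phenyl gives a 2.4-fold lower number from compound 1 to compound 4 (0.38 log units; beyond the scatter), so the chloro group on this aromatic carbon, para to a large group, is not needed for a low number, and the hydrogen compound stands lower. Within the data shown here, this is the first direct reading of a single change in the set, as the earlier compounds offered no pair differing in one place. Nothing at hand accounts for the direction of this modest step.

On these data alone, whether the number would also fall or instead rise with another group at this place, such as fluoro, methoxy or an amine, remains open. As far as these compounds go, it is also open whether a carboxylic acid or a longer chain would be accepted on this ring.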